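The source may hold more compounds than are shown below. What is called first, only, known or untested is meant among the compounds shown, and "the series" means these compounds.

Measured compounds:
compound 1, `BrCCCCOc1c(Br)cc(Br)cc1Oc1ccc(Br)cc1Br`, 29 ug/mL
compound 2, `BrCCCCCCOc1c(Br)cc(Br)cc1Oc1ccc(Br)cc1Br`, 33.8 ug/mL
compound 3, `COc1c(Br)cc(Br)cc1Oc1ccc(Br)cc1Br`, 34.5 ug/mL

In a functional assay on U-937 cells (Homo sapiens) for cytotoxicity, read by MTT assay, with a stated time of 24 h (on this read-out higher numbers stand for weaker inhibition and lower numbers for stronger inhibition), compound 3 gives 34.5 ug/mL, the highest of the three numbers, though its distance to compound 2 and to compound 1 is within the scatter on both sides. Compound 4, `CC(C)(C)C(=O)C(C#N)Oc1c(Br)cc(Br)cc1Oc1ccc(Br)cc1Br`, has not yet been measured. It differs from compound 3 at the substituent on the aromatic oxygen: cyano((tert-butyl)carbonyl)methyl in place of methyl on an oxygen on an aromatic ring.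

Within the data shown here, the steps that bear on this change are the two that alter the group on the same oxygen. The step of a 1.2-fold higher number from compound 1 to compound 3 (0.08 log units; within the scatter) and the step of a 1.0-fold higher number from compound 2 to compound 3 (0.01 log units; within the scatter) both stay within the scatter, and a 1.2-fold higher number from compound 1 to compound 2 (0.07 log units; within the scatter) likewise. The group on this oxygen has therefore, in this series, not moved the read-out beyond the scatter, though the entering group in compound 4 is unlike any chain tried so far. The expected step of a 1.0-fold lower number from compound 3 to compound 4 (0.01 log units; within the scatter) is accordingly none beyond the scatter. For compound 4 in this assay the estimate is 34 ug/mL, within a range from 15 ug/mL to 75 ug/mL.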

Compound 4, half-maximal inhibitory concentration: 32.5 ug/mL
Estimate against measurement, compound 4: 1.0-fold (0.02 log units) above, and the stated range covers the measured number.
By their numbers in this assay, from the lowest: compounds 1, 4, 2 and 3 (each within the scatter of the next).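

In this assay, among these compounds, the earlier compounds carried only methyl, 4-bromobutyl and 6-bromohexyl on this oxygen, so the flat read-out had been seen only with those groups. Cyano((tert-butyl)carbonyl)methyl, which brings a nitrile, a carbonyl and hydrogen-bond acceptors that none of the others has, extends that picture: a 1.1-fold lower number from compound 3 to compound 4 (0.03 log units; within the scatter), alongside a 1.0-fold lower number from compound 2 to compound 4 (0.02 log units; within the scatter) and a 1.1-fold higher number from compound 1 to compound 4 (0.05 log units; within the scatter), and all three steps stay within the scatter. No supporting data are available to explain this lack of separation.

The compounds shown leave open whether a group of another kind on this oxygen, such as an amine, a carboxylic acid or the bare hydroxyl with hydrogen in place of methyl, would give a step beyond the scatter. They also leave open whether replacing any of the bromines on the shared core would change the read-out, since all four compounds keep them.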